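A few compounds are considered here, and "the series" means these few. Any claim that something is new, unique, unknown or untested is made for them only; others in the source may bear on it.

Compound 1 `Nc1ncnn2c([C@@H]3O[C@H](CO)[C@@H](O)[C@H]3O)cc(C#Cc3ccc(F)cc3)c12` in a functional assay on K562 cells (Homo sapiens) for antiproliferative activity, with a stated time of 72 h; on this read-out lower numbers stand for stronger inhibition and higher numbers for weaker inhibition: > 100000 nM, a limit of the assay.
Compound 2 `Nc1ncnn2c([C@@H]3O[C@H](CO)[C@@H](O)[C@H]3O)cc(-c3ccccc3)c12` in this assay: > 100000 nM, a limit of the assay.

Compound 2 thus stands only at a limit, not at a number. Compound 1 stands at the same limit. The step that the two limits leave unreadable from compound 1 to compound 2 cannot be read, because both values sit at the limit of > 100000 nM in this assay, at which 2 of the 2 values shown sit. Compound 3 `Nc1ncnn2c([C@@H]3O[C@H](CO)[C@@H](O)[C@H]3O)cc(-c3ccsc3)c12` differs from compound 2 in one place: thiophen-3-yl in place of phenyl on an aromatic carbon. Among the compounds with values here, no measured step with a readable size bears on this change, so no direction beyond the scatter can be expected, and compound 3 is expected to remain at the limit as well. Compound 3 is estimated at 100000 nM (30000 nM to 300000 nM), an expected step of a number no higher from compound 2 to compound 3 (the limit leaves the size open).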

Compound 3, half-maximal inhibitory concentration: 66400 nM
The estimate for compound 3 lay 1.5-fold (0.18 log units) above the measured number; low and high end bracket the measured number.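

Thiophen-3-yl is the first group at this aromatic carbon to give a number rather than a limit in this assay. Placing it there gives an at least 1.5-fold lower number from compound 2 to compound 3 (0.17 log units; that floor lies within the scatter), and the comparison with the larger group gives an at least 1.5-fold lower number from compound 1 to compound 3 (0.17 log units; that floor lies within the scatter). The true size of both steps stays open because compound 1 and compound 2 give no number to measure from: the limit of > 100000 nM in this assay, at which 2 of the 3 values shown sit.

The compounds shown leave open whether thiophen-3-yl differs at all from phenyl in this assay beyond the scatter. They also leave open how an amine or a carboxylic acid on this carbon would fare.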